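A Shifted Methoxyphenyl Group in a Weakly Active Series

The source may report more compounds than this note shows. Statements on the series, on what has been measured and on what is new or still open speak of the compounds shown alone.

Compound 1 `O=S(=O)(NCCNC(=S)Nc1ccc(Cl)cc1)c1ccc(-c2ccccc2OCc2ccccc2)s1`: > 50000 nM
Compound 2 `Cc1cc(C)cc(NC(=O)NCCNS(=O)(=O)c2ccc(-c3ccccc3OCc3ccccc3)s2)c1`: > 50000 nM
Compound 3 `COc1ccc(NC(=O)NCCNS(=O)(=O)c2ccc(-c3ccccc3OCc3ccccc3)s2)cc1`: > 20000 nM

In a functional assay on RS4-11 cells (Homo sapiens) for inhibition, read by CCK-8 assay, with a stated time of 48 h (a lower number here means a stronger inhibitor, a higher number a weaker inhibitor), none of these three values is a measured number; each is a limit of the assay. Compound 3 stands at > 20000 nM, which is a limit. Compounds 1 and 2 sit at the limit of > 50000 nM in this assay, at which 2 of the 3 values shown sit. The steps between them, a step that the two limits leave unreadable from compound 1 to compound 2, a step that the two limits leave unreadable from compound 1 to compound 3 and a step that the two limits leave unreadable from compound 2 to compound 3, are therefore all unreadable in size and direction.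

Compound 4 `COc1cccc(NC(=O)NCCNS(=O)(=O)c2ccc(-c3ccccc3OCc3ccccc3)s2)c1` differs from compound 3 by 3-methoxyphenyl in place of 4-methoxyphenyl on an amide-type nitrogen. For the measured compounds named here, no measured step bears readably on this change, so no step beyond the scatter can be expected from it. Compound 4 is estimated at 30000 nM, within 8000 nM to 100000 nM, an expected step that the limit leaves unreadable from compound 3 to compound 4.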

Compound 4, half-maximal inhibitory concentration: > 20000 nM
Compound 4: only a limit was reported; the forecaster's own chance of this, stated with the estimate: 80%; the middle value does not contradict the limit.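

Compound 3 and compound 4 both carry only limits, so no step can be read between them, nor from compound 1 or compound 2 to compound 4. As far as these compounds go, whether 3-methoxyphenyl and 4-methoxyphenyl differ at all in this assay stays open.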